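This account rests on a few compounds, and the source may have more. Where it says the series, first, only, none or still open, it means among the compounds named here.

Within the data shown here, in a functional assay on NCI-H630 cells (Homo sapiens) for cytotoxicity, read by sulforhodamine B assay, with a stated time of 5 days (on this read-out higher numbers stand for weaker inhibition and lower numbers for stronger inhibition), compound 1 `O=C(CCCCc1ccccc1)CC(=O)N[C@H]1CCOC1=O` gives 80000 nM, the only exact number so far. Compound 2 `O=C(CCCc1ccccc1)CC(=O)N[C@H]1CCOC1=O` reads > 100000 nM, which is a limit of the assay and not a number. Compound 3 `O=C(CCCCCc1ccccc1)CC(=O)N[C@H]1CCOC1=O` changes compound 1 in the opposite sense to compound 2: benzyl in place of phenyl on a saturated chain carbon, four bonds along the chain from a carbonyl carbon. Among the measured compounds shown here, only one measured step bears on this, an at least 1.2-fold higher number from compound 1 to compound 2 (0.09 log units; that floor lies within the scatter), so it gives weak guidance. A small move toward stronger inhibition, within the usual scatter, is expected, a 1.6-fold lower number from compound 1 to compound 3 (0.20 log units; within the scatter). Compound 3 is estimated at 50000 nM, with an expected range of 20000 nM to 120000 nM.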

Compound 3, half-maximal inhibitory concentration: 24000 nM
For compound 3 the middle estimate is 2.1-fold (0.32 log units) above the measured one, and the stated range covers the measured number.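

Benzyl in place of phenyl, on a saturated chain carbon, four bonds along the chain from a carbonyl carbon, gives the first step here that can be sized beyond the scatter: a 3.3-fold lower number from compound 1 to compound 3 (0.52 log units; beyond the scatter). This shows that the position responds to a change, with stronger inhibition on this read-out. From the compounds shown here alone, compound 2 gives a limit and not a number, so its step gives no size: the limit of > 100000 nM in this assay, at which 1 of the 3 values shown sits. Whether a longer chain would lower the number further stays open, as does the effect of an amine or a carboxylic acid at this place.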